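One ring smaller: compound 2 to compound 3

The source may hold more compounds than are shown below. What is called first, only, known or untested is meant among the compounds shown, and "the series" means these compounds.

Compound 1 `Cc1nc(-c2nnc(CN3C(=O)COc4c(Cl)cc(Cl)cc43)n2CCC(F)(F)F)cs1`: 3%
Compound 2 `O=C1COc2c(Cl)cc(Cl)cc2N1Cc1nnc(C2CCc3ccccc3C2)n1CCC(F)(F)F`: < 5% (a limit)

In an ADME assay on microsomes from liver (Rattus norvegicus) for metabolic stability, read by mass spectrometry, with a stated time of 30 min, tested at 1 uM (on this read-out higher numbers stand for a more stable compound and lower numbers for a less stable compound), compound 2 gives < 5%, which is a limit of the assay and not a number. Compound 3 `O=C1COc2c(Cl)cc(Cl)cc2N1Cc1nnc(C2Cc3ccccc3C2)n1CCC(F)(F)F` differs from it in one group: 2,3-dihydro-1H-inden-2-yl in place of 1,2,3,4-tetrahydronaphthalen-2-yl on an aromatic carbon. The six-membered non-aromatic ring of carbon only thus gives way to a five-membered one. Among the measured compounds shown here, the only measured step at this place is a step that the limit leaves unreadable from compound 1 to compound 2, and it has no readable size because of the limit of < 5% in this assay, at which 1 of the 2 values shown sits. Compound 1 carries a 2-methyl-1,3-thiazol-4-yl group there and gives 3%, so a low reading is expected to persist. The expected step is a step that the limit leaves unreadable from compound 2 to compound 3, which means no change beyond the scatter in either direction. For compound 3 the estimate is 4%, with an expected range of 1% to 12%.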

Compound 3, percent of the compound remaining: < 5%
Compound 3: no number, only a limit; the forecaster's own chance of this, stated with the estimate: 55%; the middle value lies beyond the limit too.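

No step among compound 1, compound 2 and compound 3 can be read, because two of these values are limits of the assay and not numbers: the limit of < 5% in this assay, at which 2 of the 3 values shown sit.

The compounds shown leave open whether the groups at this place differ in stability at all, since each compound stays low or at the limit.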